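The source may report more compounds than this note shows. Statements on the series, on what has been measured and on what is new or still open speak of the compounds shown alone.

Three compounds built on a shared core have so far been characterised in an assay on isolated protein for binding affinity to 5-hydroxytryptamine receptor 3A (Homo sapiens); on this read-out higher numbers stand for weaker inhibition and lower numbers for stronger inhibition. Compound 1 `COc1ccc(-c2n[nH]cc2N2CCCNCC2)cc1` gives 1230 nM in this assay. Compound 2 `c1ccc(-c2n[nH]cc2N2CCNCC2)cc1` reaches only the limit of this assay, > 10000 nM, and no number. Compound 3 `Clc1ccc(-c2n[nH]cc2N2CCNCC2)cc1` gives 1790 nM in this assay. The change from compound 2 to compound 3, chloro in place of hydrogen on an aromatic carbon, produces an at least 5.5-fold lower number from compound 2 to compound 3 (0.74 log units; beyond the scatter), and the size of that step is bounded by the limit of > 10000 nM in this assay, at which 1 of the 3 values shown sits. Among the two numbers shown, compound 3 and compound 1 lie within the scatter of each other.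

Compound 4 `Cc1ccc(-c2n[nH]cc2N2CCNCC2)cc1` differs from compound 3 by methyl in place of chloro on an aromatic carbon. Among the measured compounds shown here, the only measured step that touches this position is the one from compound 2 to compound 3, which shows that a substituent there is favourable, but no measured step compares methyl with chloro. Compound 4 is therefore expected to give a step of a 1.4-fold higher number from compound 3 to compound 4 (0.15 log units; within the scatter), and its estimated value is 2500 nM, within a range from 900 nM to 8000 nM.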

Compound 4, inhibition constant: > 10000 nM
Compound 4 ended at the assay's limit; the forecaster's own chance of this, stated with the estimate: 15%; at least 4.0-fold (0.60 log units) between middle value and limit.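

Exchanging chloro for methyl gives an at least 5.5-fold higher number from compound 3 to compound 4 (0.74 log units; beyond the scatter), so at this position, para to a large group, these two groups of one heavy atom each are not interchangeable in this assay. The earlier step showed only that chloro gives a lower number than hydrogen; this one shows that the lower number depends on which group is present, not merely on hydrogen being replaced. The step between hydrogen and methyl cannot be read, so whether methyl changes anything at all stays unknown, as compound 2 and compound 4 both stand at a limit: the limit of > 10000 nM in this assay, at which 2 of the 4 values shown sit.

On these data alone, whether the lower number is particular to chloro or also appears with fluoro, bromo, trifluoromethyl or nitrile at this position remains open. Compound 1 differs from compound 3 in more than one place, so it cannot settle how its methoxy group compares.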